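Fluoromethyl Added to the Bicyclic Ether Core

The compounds below may be only part of what the source reports. "The series", "measured", "known", "first", "only" and "open" are said of these compounds alone.

Measured so far:
compound 1, `CNC(=O)c1cc(C(=O)N[C@H]2[C@@H]3COC[C@@H]32)cc2c1OC[C@H]2c1ccccc1`, 3.3
compound 2, `CNC(=O)c1cc(C(=O)NC)c2c(c1)[C@H](c1ccccc1)CO2`, 3.2
compound 3, `CCC(=O)N1C[C@@H]2[C@H](C1)[C@H]2NC(=O)c1cc(C(=O)NC)c2c(c1)[C@H](c1ccccc1)CO2`, 3.4

All three were examined in a physicochemical assay for lipophilicity, at pH 7.4; on this read-out lower numbers stand for lower lipophilicity and higher numbers for higher lipophilicity. Compound 1 stands second highest of the three numbers; its nearest neighbour is compound 2, with a number 0.10 log units lower from compound 1 to compound 2 (within the scatter), and its furthest is compound 3, with a number 0.10 log units higher from compound 1 to compound 3 (within the scatter). The remaining step, a number 0.20 log units higher from compound 2 to compound 3 (within the scatter), also stays within the scatter, so the three measured compounds cannot be told apart on this read-out.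

Compound 4, `CNC(=O)c1cc(C(=O)N[C@H]2[C@@H]3COC[C@@H]32)cc2c1O[C@H](CF)[C@H]2c1ccccc1`, differs from compound 1 by fluoromethyl in place of hydrogen on a saturated ring carbon. Every measured step changes the group on an amide-type nitrogen, not the saturated ring carbon, so none of them bears directly on this change. Replacing a hydrogen atom by a fluoromethyl group adds heavy atoms and usually moves lipophilicity modestly upward; an increase beyond the scatter is plausible but not assured. Compound 4 is therefore expected to give 3.6, within a range of 3.2 to 4, meaning an estimated step of a number 0.30 log units higher from compound 1 to compound 4 (within the scatter).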

Compound 4, distribution coefficient: 3.6
The estimate for compound 4 equals the measured number at the digits printed; the measured number falls inside the stated range.
By their numbers in this assay, from the lowest: compounds 2, 1, 3 and 4 (each within the scatter of the next, the first and the last beyond it).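

For the compounds shown here, every earlier step changed the group on an amide-type nitrogen, so compound 4 gives the first reading at this saturated ring carbon, next to the ring oxygen. In this assay fluoromethyl in place of hydrogen here comes to a number 0.30 log units higher from compound 1 to compound 4 (within the scatter) and so compound 1 and compound 4 cannot be told apart. Nothing available gives a reason for this result.

Going by these compounds, whether another group on the same carbon, such as hydroxymethyl, an amine or a longer chain, would give a step beyond the scatter remains open. Also open, on these data alone, is whether fluoromethyl would read the same way with the groups on the amide-type nitrogen of compound 2 or compound 3.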